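Trifluoromethoxy for acetyl in the cytotoxicity series

A few compounds are considered here, and "the series" means these few. Any claim that something is new, unique, unknown or untested is made for them only; others in the source may bear on it.

Measured so far in an ADME assay on HepG2 cells (Homo sapiens) for cytotoxicity, with a stated time of 72 h; a lower number here means that less compound is needed, a higher number that more compound is needed for the effect

- compound 1 `CC(=O)c1ccc(NC(=O)Nc2cc(C)nc3ccccc23)cc1` gives 19000 nM
- compound 2 `Cc1cc(NC(=O)Nc2ccc(F)c(F)c2)c2ccccc2n1` gives 21000 nM
- compound 3 `Cc1cc(NC(=O)Nc2cccc3nsnc23)c2ccccc2n1` gives > 25000 nM as a limit

Among the numbers, compound 1 at 19000 nM and compound 2 at 21000 nM lie within the scatter of each other. Compound 3 gives > 25000 nM, which is a limit of the assay and not a number.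

Next in this assay is compound 4 `Cc1cc(NC(=O)Nc2ccc(OC(F)(F)F)cc2)c2ccccc2n1`, which keeps the core of compound 1 and carries trifluoromethoxy in place of acetyl on an aromatic carbon, para to a large group (trifluoromethoxy in place of acetyl on an aromatic carbon). For the measured compounds named here, no measured pair differs in one place only, so the size of this step has no direct precedent. The expectation rests on compound 2 at 21000 nM, whose number stays level with that of compound 1 despite a different substitution. A small move toward a lower number is expected, probably not beyond the scatter, and the estimated step is a 1.3-fold lower number from compound 1 to compound 4 (0.10 log units; within the scatter) (an expectation only). Compound 4 is estimated at 15000 nM (expected range 6000 nM to 25000 nM).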

Compound 4, half-maximal effective concentration: 15000 nM
For compound 4 middle estimate and measured number coincide at the digits printed; the range from low to high includes it.
By their numbers in this assay, from the lowest: compounds 4, 1 and 2 (each within the scatter of the next). At a limit, above all of these: compound 3.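

For the compounds shown here, this is the first step that can be read at a single place: in this assay, trifluoromethoxy in place of acetyl on an aromatic carbon, para to a large group, gives a 1.3-fold lower number from compound 1 to compound 4 (0.10 log units; within the scatter). At this position the two groups cannot be told apart by this read-out, even though the double bond of acetyl leaves and three fluorines enter. Compound 3 stands at a limit of the assay and not at a number, so it adds no step here: the limit of > 25000 nM in this assay, at which 1 of the 4 values shown sits.

Going by these compounds, whether an amine, a carboxylic acid or a longer chain at this position would move the number beyond the scatter stays open. Going by these compounds alone, also open is what a change to the shared core would do, since the one readable step touches only this substituent.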